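Propyl for isopropyl on the diene chain of compound 3

The compounds below may be only part of what the source reports. "The series", "measured", "known", "first", "only" and "open" are said of these compounds alone.

Compound 1 `CCCC/C(=C\C=C\C(=O)N[C@H](C)CCCc1cccnc1)c1ccc(OC)cc1` gives 0.68 mg/kg in a functional assay with platelet-activating factor receptor (Cavia porcellus) as the target; a lower number here means that less compound is needed, a higher number that more compound is needed for the effect.
Compound 2 `O=C(C=C(c1ccccc1)c1ccccc1)NCCCCc1cccnc1` gives 0.58 mg/kg in this assay.
Compound 3 `COc1ccc(/C(=C/C=C/C(=O)N[C@H](C)CCCc2cccnc2)C(C)C)cc1` gives 0.41 mg/kg in this assay.

Compound 3 holds the lowest of the three numbers, yet its gaps to compound 2 and compound 1 both sit within the scatter, so no order among them can be read. Compound 4 `CCC/C(=C\C=C\C(=O)N[C@H](C)CCCc1cccnc1)c1ccc(OC)cc1` differs from compound 3 by propyl in place of isopropyl on a double-bonded chain carbon bound to an aromatic carbon and a double-bonded chain carbon. Among the measured compounds shown here, the one step that touches the same place is a 1.7-fold lower number from compound 1 to compound 3 (0.22 log units; within the scatter), a change inside the scatter. Since that chain variation moved the number little, the change to propyl is expected to stay within the scatter as well, a step of a 1.2-fold higher number from compound 3 to compound 4 (0.09 log units; within the scatter) being estimated. Compound 4 is therefore expected to give about 0.5 mg/kg, in the range 0.25 mg/kg to 1 mg/kg.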

Compound 4, dose for 50% inhibition: 0.52 mg/kg
The estimate for compound 4 lay 1.0-fold (0.02 log units) below the measured number; low and high end bracket the measured number.
By their numbers in this assay, from the lowest: compounds 3, 4, 2 and 1 (each within the scatter of the next).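

Propyl in place of isopropyl on this double-bonded chain carbon gives a 1.3-fold higher number from compound 3 to compound 4 (0.10 log units; within the scatter) in this assay, and propyl in place of butyl gives a 1.3-fold lower number from compound 1 to compound 4 (0.12 log units; within the scatter). At this place, therefore, the numbers do not tell isopropyl, propyl and butyl apart, whether the chain is branched or straight. No measurement at hand bears on why the numbers stay so close. Going by these compounds, whether a longer chain such as octyl, or an amine or a carboxylic acid at this place, would also stay within the scatter remains open.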